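The source may hold more compounds than are shown below. What is called first, only, known or untested is meant among the compounds shown, and "the series" means these compounds.

Compound 1 `NCCNc1cc(N2CCN(C(=O)C3(c4ccccc4)CCCC3)CC2)nc2ccccc12`: > 100000 nM
Compound 2 `NCCNc1cc(N2CCN(C(=O)C3(c4ccccc4)CCC3)CC2)nc2ccccc12`: > 100000 nM

In an ADME assay on HEp-2 cells (Homo sapiens) for cytotoxicity, read by CCK-8 assay, with a stated time of 6 days (on this read-out lower numbers stand for higher toxicity in this test and higher numbers for lower toxicity in this test), compound 1 gives > 100000 nM, which is a limit of the test and not a number. Compound 2 gives > 100000 nM, likewise a limit. The step that the two limits leave unreadable from compound 1 to compound 2 therefore cannot be sized. Compound 3 `NCCNc1cc(N2CCN(C(=O)C3(c4ccccc4)CC3)CC2)nc2ccccc12` differs from compound 2 by 1-phenylcyclopropyl in place of 1-phenylcyclobutyl on a carbonyl carbon. Going by the values given here, no measured step bears readably on this change; what the data do show is the limit of > 100000 nM in this assay, at which 2 of the 2 values shown sit, with neither compound reaching measurable toxicity. The step of a number no higher from compound 2 to compound 3 (the limit leaves the size open) is expected to stay within the scatter, most likely ending again at a limit. The estimate for compound 3 is 100000 nM, ranging from 50000 nM to 200000 nM.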

Compound 3, half-maximal cytotoxic concentration: > 100000 nM
Compound 3 was reported as a limit; the forecaster's own chance of this, stated with the estimate: 85%; the middle value sits exactly at the limit.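

Compound 3, like compound 1 and compound 2, gives only a limit, so no step among these compounds can be read in this assay. The compounds shown leave open how far any of them lies from measurable toxicity: the limit of > 100000 nM in this assay, at which 3 of the 3 values shown sit.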